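The compounds below may be only part of what the source reports. "The series", "measured", "known", "first", "only" and "open" are said of these compounds alone.

Compound 1 `Cc1nc(-c2ccccc2)c(C(=O)N2CCN(c3ccc(Cl)c(Cl)c3)CC2)o1`: 124 nM
Compound 2 `Cc1nc(-c2ccccc2)c(C(=O)N2CCN(c3ccccc3F)CC2)o1`: 147 nM

For the measured compounds named here, in a functional assay on HL-60 cells (Homo sapiens) for inhibition, read by MTT assay, with a stated time of 72 h (on this read-out lower numbers stand for stronger inhibition and higher numbers for weaker inhibition), compound 2 gives 147 nM, which lies within the scatter of the only other number, that of compound 1. Compound 3 `Cc1nc(-c2ccccc2)c(C(=O)N2CCN(c3ccc(C)c(C)c3)CC2)o1` keeps the shared core and has 3,4-dimethylphenyl in place of 2-fluorophenyl on an amine nitrogen in a ring. Going by the values given here, one measured step bears on this change, a 1.2-fold higher number from compound 1 to compound 2 (0.07 log units; within the scatter), made at the same place. That exchange of 3,4-dichlorophenyl for 2-fluorophenyl stayed within the scatter. Among the compounds with values here, no compound carrying methyl groups on this ring has been measured, so the evidence is thin. No step beyond the scatter is expected in this assay, and no direction can be favoured. The expected change is a 1.1-fold lower number from compound 2 to compound 3 (0.04 log units; within the scatter). Compound 3 is estimated at 135 nM, with an expected range from 60 nM to 300 nM.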

Compound 3, half-maximal inhibitory concentration: 43 nM
Beside the measured number, compound 3's estimate is 3.1-fold (0.50 log units) above it; the measured number lies below the stated range.
By their numbers in this assay, from the lowest: compound 3; then compounds 1 and 2 (each within the scatter of the next).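

For the compounds shown here, at this position, the group on the amine nitrogen in a ring can move the number beyond the scatter in this assay, which the first pair of compounds did not show: 3,4-dimethylphenyl in place of 2-fluorophenyl gives a 3.4-fold lower number from compound 2 to compound 3 (0.53 log units; beyond the scatter), and in place of 3,4-dichlorophenyl it gives a 2.9-fold lower number from compound 1 to compound 3 (0.46 log units; beyond the scatter). The second step exchanges only the chlorine atoms of 3,4-dichlorophenyl for the methyl groups of 3,4-dimethylphenyl, so the placing that these two groups share does not alone go with the lower number among these compounds. The data offer no measurement that could account for this difference.

The compounds shown leave open whether a single methyl group, as in 4-methylphenyl, would give the same result. They also leave open how 3,4-dimethoxyphenyl or 3,4-diethylphenyl would compare with 3,4-dimethylphenyl.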